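From benzyl to 1-phenylethyl in compound 4

A few compounds are considered here, and "the series" means these few. Any claim that something is new, unique, unknown or untested is made for them only; others in the source may bear on it.

In a physicochemical assay for solubility, read by HPLC, in phosphate buffer, with a stated time of 24 h, at pH 7.4, tested at 100 uM (a lower number here means a less soluble compound, a higher number a more soluble compound), compound 1 `O=C(CCCCCCNc1c(Nc2ccccc2)c(=O)c1=O)NO` gives 6000000 nM and compound 2 `O=C(CCCCNc1c(Nc2ccccc2)c(=O)c1=O)NO` gives 87000000 nM. Compound 3 `O=C(CCCCCNc1c(NCc2ccccc2)c(=O)c1=O)NO` gives 75000000 nM, which lies within the scatter of compound 2 and beyond the scatter of compound 1. Compound 4 `C[C@H](Nc1c(NCCCCCC(=O)NO)c(=O)c1=O)c1ccccc1` differs from compound 3 in one place: methyl in place of hydrogen on a saturated chain carbon bound to an aromatic carbon and a nitrogen on an aromatic ring, which reads as benzyl to 1-phenylethyl. Among the compounds with values here, the only measured step, a 15-fold higher number from compound 1 to compound 2 (1.16 log units; beyond the scatter), is large, but it changes the chain bearing the hydroxycarbamoyl group and not this place, so it bears only loosely on the question. Within the data shown here, no measured step tests this change directly. A modest move to a lower number in this assay is expected, estimated as a 1.7-fold lower number from compound 3 to compound 4 (0.22 log units; within the scatter). Compound 4 is expected at 45000000 nM, with an estimated range of 15000000 nM to 95000000 nM.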

Compound 4, solubility: 73000000 nM
Compound 4: middle estimate off by 1.6-fold (0.21 log units), on the low side, and the stated range covers the measured number.
By their numbers in this assay, from the lowest: compound 1; then compounds 4, 3 and 2 (each within the scatter of the next).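

In this assay, the change from benzyl to 1-phenylethyl gives a 1.0-fold lower number from compound 3 to compound 4 (0.01 log units; within the scatter), so this position carries the added methyl with no difference beyond the scatter. The earlier compounds shown here offered no step at this place, only one in the chain bearing the hydroxycarbamoyl group. No evidence at hand bears on this result.

The compounds shown leave open whether an ethyl group, an amine or a carboxylic acid on this same carbon would also stay within the scatter of compound 3. They also leave open how the mirror-image 1-phenylethyl group would compare with compound 4.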